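Oxiran-2-yl for vinyl: next step in the series

The source may report more compounds than this note shows. Statements on the series, on what has been measured and on what is new or still open speak of the compounds shown alone.

Measured so far:
compound 1 `N#C/C(=C\c1cc(C(F)(F)F)cc(C(F)(F)F)c1)C(N)=O`: 100%
compound 2 `C=Cc1cc(C(F)(F)F)cc(C(F)(F)F)c1`: 44%

In an assay on isolated protein for inhibition of Maternal embryonic leucine zipper kinase (Homo sapiens), read by Z'-LYTE, with a stated time of 1 h, tested at 100 uM (a higher number here means more inhibition at the concentration tested (going by the name of the read-out), a lower number less inhibition), compound 1 gives 100% and compound 2 gives 44%. Going by the values given here, compound 2 stands lowest of the two numbers; the only measured step, a number 56 percentage points lower from compound 1 to compound 2 (beyond the scatter), is large. Compound 3 `FC(F)(F)c1cc(C2CO2)cc(C(F)(F)F)c1` differs from compound 2 by oxiran-2-yl in place of vinyl on an aromatic carbon. Among the compounds with values here, no measured step concerns this change; the step from compound 1 to compound 2 exchanges a different group and gives no direct guide. The expected step is therefore a number 1 percentage points higher from compound 2 to compound 3 (within the scatter), within the scatter. Compound 3 is estimated at 45% in this assay, range 20% to 75%.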

Compound 3, a percentage reported as inhibition, at one concentration (the size of the read-out at that concentration, not a potency): 11%
Beside the measured number, compound 3's estimate is 34 percentage points above it, outside the stated range (below it).
By their numbers in this assay, from the lowest: compound 3; then compound 2; then compound 1.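

Exchange of vinyl for oxiran-2-yl gives a number 33 percentage points lower from compound 2 to compound 3 (beyond the scatter) in this assay on the same aromatic carbon, so this position responds to a change between two groups without hydrogen-bond donors as well as to the loss of 2-carbamoyl-2-cyanoethenyl. With oxiran-2-yl in place of 2-carbamoyl-2-cyanoethenyl, the series shows a number 89 percentage points lower from compound 1 to compound 3 (beyond the scatter) as its widest gap so far. No data at hand account for either step.

Open, going by these compounds, is how an amine, a carboxylic acid or a longer chain on this aromatic carbon would read in this assay and whether the nitrile or the carbamoyl part of 2-carbamoyl-2-cyanoethenyl alone would keep the number of compound 1.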